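The compounds below may be only part of what the source reports. "The series", "measured", "known", "first", "only" and "open" are said of these compounds alone.

Measured compounds:
Compound 1 `COc1cc(/C=C2\CCC/C(=C\c3ccccc3[N+](=O)[O-])C2=O)cc(OC)c1OC` gives 4.86 in a physicochemical assay for lipophilicity; a lower number here means a more polar compound, a higher number a more lipophilic compound.
Compound 2 `Cc1ccc(/C=C2\CCC/C(=C\c3ccccc3[N+](=O)[O-])C2=O)cc1` gives 4.86 in this assay.

Compound 1 stands level with compound 2 at the digits shown; the two values are within the scatter of each other, so nothing can be said of an order between them in this assay. For the measured compounds named here, only these two measurements are known, and no step between compounds that differ in one place has been recorded.

Compound 3 `COc1cc(/C=C2\CCC/C(=C\c3cccc([N+](=O)[O-])c3)C2=O)cc(OC)c1OC` has not yet been measured. It differs from compound 1 in one place: 3-nitrophenyl in place of 2-nitrophenyl on a double-bonded chain carbon bound to a double-bonded ring carbon. The same atoms are present in both, joined differently, and no other part of the structure changes.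

Without a measured step of this kind to lean on, the change from compound 1 to compound 3 is expected to give at most a small shift, no larger than the scatter, in either direction. The expected step is a number 0.09 log units higher from compound 1 to compound 3 (within the scatter). For compound 3 the estimate in this assay is 4.95, with a range from 4.5 to 5.4.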

Compound 3, partition coefficient: 5.06
The estimate for compound 3 lay 0.11 log units below the measured number; the measured number falls inside the stated range.
By their numbers in this assay, from the lowest: compounds 1, 2 and 3 (each within the scatter of the next).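

For the compounds shown here, the exchange of 2-nitrophenyl for 3-nitrophenyl on a double-bonded chain carbon bound to a double-bonded ring carbon gives the first step between compounds differing in one place in this assay: a number 0.20 log units higher from compound 1 to compound 3 (within the scatter). With the same atoms present and joined differently, this exchange at this place therefore does not carry the number beyond the scatter, at least on the core of compound 1. Nothing available bears on why the step has this size.

As far as these compounds go, whether the same exchange made on compound 2 would give a step of similar size remains open. From the compounds shown here alone, it is also open whether an aminophenyl or a carboxyphenyl group at this place, with different atoms rather than the same atoms rearranged, would stay within the scatter of compound 1.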